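Trimming the Side Chain of Compound 2 Down to Hydroxy

The source may hold more compounds than are shown below. What is called first, only, known or untested is meant among the compounds shown, and "the series" means these compounds.

compound 1 `Cc1cc(N)nc(CC(C)C)c1`: 193 nM
compound 2 `Cc1cc(N)nc(CC(C)OCCF)c1`: > 5000 nM

In an assay on isolated protein for inhibition of Nitric oxide synthase, inducible (Homo sapiens), with a stated time of 30 min (a lower number here means a stronger inhibitor, a higher number a weaker inhibitor), compound 1 gives 193 nM. For compound 2 the reported value > 5000 nM is a limit of the assay, not a number. Compound 2 therefore stands at the limit of > 5000 nM in this assay, at which 1 of the 2 values shown sits, and only that boundary is known for it. Among the compounds with values here, the one measured step, an at least 25-fold higher number from compound 1 to compound 2 (1.41 log units; beyond the scatter), is large.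

Compound 3 `Cc1cc(N)nc(CC(C)O)c1` differs from compound 2 by hydrogen in place of 2-fluoroethyl on an oxygen on a saturated carbon. The measured step bears on this change only partly: it shows a large loss when 2-fluoroethoxy replaces methyl, but the hydroxy of compound 3 is neither the methyl of compound 1 nor the 2-fluoroethoxy of compound 2. Since compound 2 itself is known only as a limit, the size of any recovery is uncertain. A moderate gain is expected, roughly an at least 2.5-fold lower number from compound 2 to compound 3 (0.39 log units; beyond the scatter). Compound 3 is thus estimated at 2000 nM, within 400 nM to 10000 nM.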

Compound 3, half-maximal inhibitory concentration: 1780 nM
Compound 3: the middle estimate sits 1.1-fold (0.05 log units) above what was measured, and the stated range covers the measured number.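

In this assay, hydrogen in place of 2-fluoroethyl on the oxygen gives an at least 2.8-fold lower number from compound 2 to compound 3 (0.44 log units; beyond the scatter), so part of the loss seen with 2-fluoroethoxy is regained once the 2-fluoroethyl is gone. Compound 2 is a limit, not a number, so this gain has only a lower bound: the limit of > 5000 nM in this assay, at which 1 of the 3 values shown sits. Yet the recovery is not complete, for hydroxy in place of methyl still gives a 9.2-fold higher number from compound 1 to compound 3 (0.96 log units; beyond the scatter), which shows that even this small oxygen-bearing group on the saturated chain carbon falls short of methyl in this assay.

On these data alone, whether an amine or a methoxy on this carbon would sit nearer to methyl or to hydroxy stays open. Also open, as far as these compounds go, is whether an ethoxy without its fluorine would behave like 2-fluoroethoxy.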